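Methoxy for Fluoro on Two Related Cores

This account rests on a few compounds, and the source may have more. Where it says the series, first, only, none or still open, it means among the compounds named here.

Compound 1 `COC(=O)[C@@]1(C)CCC=C2[C@@H]1CC[C@@H](C)[C@]2(C)Cc1c(C)[nH]c2ccc(F)cc12` and compound 2 `COC(=O)[C@@]1(C)CCC=C2[C@@H]1CC[C@@H](C)[C@]2(C)Cc1c(C)[nH]c2ccc(OC)cc12` share one core and differ in a single place: methoxy in place of fluoro on an aromatic carbon. In a functional assay on A549 cells (Homo sapiens) for inhibition, read by sulforhodamine B assay, with a stated time of 48 h (a higher number here means a weaker inhibitor of growth, a lower number a stronger inhibitor of growth), compound 1 gives 15000 nM, while compound 2 gives 16000 nM, so that a 1.1-fold higher number from compound 1 to compound 2 (0.03 log units; within the scatter). Compound 3 `COC(=O)[C@@]1(C)CC[C@@H]2C3=C1CC[C@@H](C)[C@]3(C)C[C@@H]1c3cc(F)ccc3N[C@H]21` is built on a different core; the difference between the two cores is not broken down here. In this assay compound 3 gives 25000 nM. Compound 4 `COC(=O)[C@@]1(C)CC[C@@H]2C3=C1CC[C@@H](C)[C@]3(C)C[C@@H]1c3cc(OC)ccc3N[C@H]21` differs from compound 3 by methoxy in place of fluoro on an aromatic carbon, the same kind of change as before, set here in a fused or bridged system of five rings rather than two. The step of a 1.1-fold higher number from compound 3 to compound 4 (0.03 log units; within the scatter) is expected to be small, because a 1.1-fold higher number from compound 1 to compound 2 (0.03 log units; within the scatter) stayed within the scatter. Compound 4 is therefore estimated at 27000 nM, with a likely range from 12000 nM to 55000 nM.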

Compound 4, concentration for 50% growth inhibition: 22000 nM
For compound 4 the middle estimate is 1.2-fold (0.09 log units) above the measured one; the measured number falls inside the stated range.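

On the core of compound 3, methoxy in place of fluoro gives a 1.1-fold lower number from compound 3 to compound 4 (0.06 log units; within the scatter). Set beside the same change on the core of compound 1, the step carries over with no difference that can be read: the same change on two cores in this assay, a 1.1-fold higher number (0.03 log units; within the scatter) from compound 1 to compound 2 and a 1.1-fold lower number (0.06 log units; within the scatter) from compound 3 to compound 4, 1.2-fold (0.08 log units) apart, within the scatter of two such steps. This shows that in this assay the change stays within the scatter on both cores, but it does not show that a step of real size would carry over, since neither core gives one, and two pairs support no rule for the series.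

The compounds shown leave open whether another group on this aromatic carbon, such as an amine or a carboxylic acid, would give a step beyond the scatter. They also leave open whether such a step would hold on both cores.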